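A few compounds are considered here, and "the series" means these few. Any claim that something is new, unique, unknown or untested is made for them only; others in the source may bear on it.

Series notes. Compound 1 `COc1ccc(O)c(C(=O)Nc2ccc(C#N)cc2)c1` is the reference point of this set. In a functional assay on KG-1 cells (Homo sapiens) for cytotoxicity, read by luminescence and CellTiter-Glo, with a stated time of 3 days (a higher number here means a weaker inhibitor, a lower number a stronger inhibitor), compound 1 does not reach a number and stops at the limit of the assay, > 10000 nM. Compound 2 `N#Cc1ccc(Nc2n[nH]c3ccccc23)cc1` shares the nitrile-bearing aniline part. In this assay compound 2 likewise stops at the limit, > 10000 nM. Where compound 1 stands is therefore known only as a limit: the limit of > 10000 nM in this assay, at which 2 of the 2 values shown sit, so no number separates it from compound 2. Among the compounds with values here, no step between two measured compounds can be drawn from this.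

The next compound, compound 3 `N#Cc1ccc(NC(=O)c2ccccc2O)cc1`, differs from compound 1 in one place: hydrogen in place of methoxy on an aromatic carbon. The hydroxy group and the amide remain as in compound 1. With both shown values sitting at the limit, no measured pair tells how large a step this change makes in this assay.

The step from compound 1 to compound 3 is expected to be a step that the limit leaves unreadable from compound 1 to compound 3, that is, none beyond the scatter. This expectation rests on compound 1 giving > 10000 nM. Compound 3 is thus estimated at 15000 nM, within 5000 nM to 50000 nM, and most likely again reported only as a limit.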

Compound 3, half-maximal inhibitory concentration: 5370 nM
Compound 3: middle estimate off by 2.8-fold (0.45 log units), on the high side, within the range that was stated.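

In this assay, within the data shown here, compound 3 gives 5370 nM, the first actual number in this set, which shows that this core can register within the range of the assay when the aromatic carbon para to a hydroxy group carries hydrogen. Hydrogen in place of methoxy at this position gives an at least 1.8-fold lower number from compound 1 to compound 3 (0.27 log units; that floor lies within the scatter); only this floor is known, and on its own it does not establish a change beyond the scatter. The full size of the step stays unread because compound 1 holds only a limit: the limit of > 10000 nM in this assay, at which 2 of the 3 values shown sit.

The compounds shown leave open how this position responds to anything other than hydrogen and methoxy, such as an amine, a carboxylic acid or a longer alkoxy chain. They also leave open how the number in this assay responds to changes to the hydroxy group or the nitrile, since compound 1 and compound 3 share both.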